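Adding a Nitro Group and Tolerance in Vero Cells

The compounds below may be only part of what the source reports. "The series", "measured", "known", "first", "only" and "open" are said of these compounds alone.

Compound 1, `COc1ccc(-c2nc3cc(C(F)(F)F)ccc3[nH]2)cc1` — 15000 nM in an ADME assay on Vero cells (Chlorocebus sabaeus) for cytotoxicity; a higher number here means that more compound is tolerated, a lower number that less compound is tolerated
Compound 2, `O=[N+]([O-])c1ccc(-c2nc3ccccc3[nH]2)c([N+](=O)[O-])c1` — > 100000 nM, a limit of this assay
Compound 3, `O=[N+]([O-])c1ccccc1-c1nc2ccccc2[nH]1` — > 100000 nM, a limit of this assay

Compound 1 is the only one of the three with a plain number: in this assay compound 1 gives 15000 nM. For compound 2 the assay reports > 100000 nM, which is a limit and not a number. For compound 3 it likewise reports > 100000 nM, again a limit. Compound 3 turns into compound 2 by nitro in place of hydrogen on an aromatic carbon. The size of that step, a step that the two limits leave unreadable from compound 3 to compound 2, cannot be read because of the limit of > 100000 nM in this assay, at which 2 of the 3 values shown sit. The difference between the core of compound 1 and the core of compound 3 is not broken down here.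

Compound 4, `COc1ccc(-c2nc3cc(C(F)(F)F)ccc3[nH]2)c([N+](=O)[O-])c1`, has not yet been measured. It arises from compound 1 by nitro in place of hydrogen on an aromatic carbon, the same kind of change as from compound 3 to compound 2, though the surroundings differ: in compound 4 the new group sits ortho to a large group and meta to a methoxy group, whereas in compound 2 it sits meta to a nitro group and para to a group of 9 heavy atoms. Among the measured compounds shown here, the one measured instance of this change gives no readable size, so the expectation rests on compound 1 and its value 15000 nM alone. The expected step is a 1.3-fold higher number from compound 1 to compound 4 (0.12 log units; within the scatter), little more than the usual scatter. Compound 4 is thus estimated at 20000 nM, between 7000 nM and 60000 nM.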

Compound 4, half-maximal cytotoxic concentration: 20000 nM
For compound 4 middle estimate and measured number coincide at the digits printed; measured number inside the range.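

On the core of compound 1, nitro in place of hydrogen on an aromatic carbon gives a 1.3-fold higher number from compound 1 to compound 4 (0.12 log units; within the scatter) in this assay, so compound 1 and compound 4 cannot be told apart in this one readable instance. The same change from compound 3 to compound 2 offers no size to set beside it, so nothing can be said about whether the change carries over from one core to the other, because both of those values are limits and not numbers: the limit of > 100000 nM in this assay, at which 2 of the 4 values shown sit. The result therefore describes one core and one place, ortho to a large group and meta to a methoxy group, and it is no rule for the series.

The compounds shown leave open how an amine or a carboxylic acid at that same place on the core of compound 1 would read in this assay. They also leave open whether a longer chain in place of the methoxy group would alter the picture with the nitro group kept.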